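Pyridin-4-yl replaces methylpyridinyl on a weak oxadiazole amide

A few compounds are considered here, and "the series" means these few. Any claim that something is new, unique, unknown or untested is made for them only; others in the source may bear on it.

Of the compounds shown here, three have been measured in an assay on T-REx-293 cells for inhibition of potassium channel subfamily T member 1 (Homo sapiens), read by patch clamp; a lower number here means a stronger inhibitor, a higher number a weaker inhibitor. Compound 1 `C[C@H](NC(=O)c1cc(C2CC2)nn1C)c1nc(-c2ccccc2)no1` gives 11400 nM. Compound 2 `Cc1cccc(-c2nnc([C@H](C)NC(=O)c3cc(C4CC4)nn3C)o2)c1` reaches only the limit of the assay, > 30000 nM. Compound 3 `Cc1cccc(-c2noc([C@H](C)NC(=O)c3cc(C(F)(F)F)nn3C)n2)n1` likewise reaches only the limit, > 30000 nM. Compound 3 thus stands at the weak end of what is shown, sharing that position with compound 2, as the limit of > 30000 nM in this assay, at which 2 of the 3 values shown sit, records; compound 1 is the only one of the three with an actual number. Compound 4 `C[C@H](NC(=O)c1cc(C(F)(F)F)nn1C)c1nc(-c2ccncc2)no1` differs from compound 3 in one place: pyridin-4-yl in place of 6-methylpyridin-2-yl on an aromatic carbon. Within the data shown here, no measured pair isolates this change, and compound 1 differs from compound 4 in two places, so it gives no clean guide. Among the measured compounds shown here, with compound 3 at a limit, no step can be computed from it, and the expectation for compound 4 rests on the weak values around it. Compound 4 is expected to remain near the limit, at an estimated 25000 nM with a range from 8000 nM to 60000 nM. The step of an at least 1.2-fold lower number from compound 3 to compound 4 (0.07 log units; that floor lies within the scatter) is expected to be small or none beyond the scatter.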

Compound 4, half-maximal inhibitory concentration: 5250 nM
Beside the measured number, compound 4's estimate is 4.8-fold (0.68 log units) above it; the measured number lies below the stated range.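

In this assay, the aromatic carbon between two ring nitrogen atoms proves sensitive to the group it carries: pyridin-4-yl in place of 6-methylpyridin-2-yl gives an at least 5.7-fold lower number from compound 3 to compound 4 (0.75 log units; beyond the scatter) in this pair. Both groups are six-membered aromatic rings with one hetero atom, so a change within that single ring type is enough to yield a measured number with the rest of the molecule held constant. The step is only a floor on the true size, because compound 3 stands at a limit: the limit of > 30000 nM in this assay, at which 2 of the 4 values shown sit.

The compounds shown leave open whether the gain follows the loss of the methyl or the new location of the ring nitrogen, a question that unsubstituted pyridin-2-yl would separate. From the compounds shown here alone, whether pyridin-3-yl, or an amine on the pyridin-4-yl ring, would lower the number further also remains open.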